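A Nitro Group Tested on the Amide Phenyl Ring

The compounds below may be only part of what the source reports. "The series", "measured", "known", "first", "only" and "open" are said of these compounds alone.

Three measured compounds share one core and differ only in the group on the amide nitrogen. In an assay on isolated protein for inhibition of histone deacetylase 8 (Homo sapiens), with a stated time of 1 h (a higher number here means a weaker inhibitor, a lower number a stronger inhibitor), compound 1 `COc1cccc(NC(=O)COc2ccc3cc(/C=C4/SC(=O)NC4=O)ccc3c2)c1` gives 7600 nM. Compound 2 `Cc1cc(NC(=O)COc2ccc3cc(/C=C4/SC(=O)NC4=O)ccc3c2)no1` reaches only the limit of > 50000 nM in this assay. Compound 3 `O=C(COc1ccc2cc(/C=C3/SC(=O)NC3=O)ccc2c1)Nc1ccccc1`, carrying an unsubstituted phenyl on the amide nitrogen, gives 4500 nM in this assay, the lowest of the two numbers obtained; the nearest other number lies within the scatter, since a 1.7-fold lower number from compound 1 to compound 3 (0.23 log units; within the scatter). Exchanging the ring itself mattered more: an at least 6.5-fold higher number from compound 1 to compound 2 (0.81 log units; beyond the scatter) and an at least 11-fold lower number from compound 2 to compound 3 (1.04 log units; beyond the scatter).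

Compound 4 `O=C(COc1ccc2cc(/C=C3/SC(=O)NC3=O)ccc2c1)Nc1ccc([N+](=O)[O-])cc1` keeps the phenyl ring of compound 3 and adds one change: nitro in place of hydrogen on an aromatic carbon. Among the compounds with values here, the only measured step that alters a substituent on that ring, rather than the ring itself, is the one from compound 1 to compound 3, which stayed within the scatter. A step of about that size is therefore expected, in either direction or none at all. Compound 4 is expected to give 4000 nM, with a range from 1500 nM to 12000 nM. That estimate means a 1.1-fold lower number from compound 3 to compound 4 (0.05 log units; within the scatter).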

Compound 4, half-maximal inhibitory concentration: 4000 nM
Compound 4: middle estimate and measured number agree at the digits printed; the range from low to high includes it.
By their numbers in this assay, from the lowest: compounds 4, 3 and 1 (each within the scatter of the next). At a limit, above all of these: compound 2.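

In this assay, a nitro group on the phenyl ring, para to a large group, gives no step beyond the scatter, either against the unsubstituted phenyl (a 1.1-fold lower number from compound 3 to compound 4 (0.05 log units; within the scatter)) or against the 3-methoxyphenyl group (a 1.9-fold lower number from compound 1 to compound 4 (0.28 log units; within the scatter)). Within the data shown here, with this larger substituent too, the one large step is the one that exchanges the ring itself (an at least 12-fold lower number from compound 2 to compound 4 (1.09 log units; beyond the scatter)). Compound 2 is held at a limit, not a number: the limit of > 50000 nM in this assay, at which 1 of the 4 values shown sits.

Still open, on these data alone, is whether any substituent on this phenyl ring can move the number beyond the scatter, for example an amine or a carboxylic acid in the place of the nitro group. Among these compounds, only one ring other than phenyl appears here, in compound 2, and a pyridine ring on the amide nitrogen remains an open case.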